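From ethoxy to trifluoromethoxy on the shared core

The source may report more compounds than this note shows. Statements on the series, on what has been measured and on what is new or still open speak of the compounds shown alone.

In a functional assay on KB cells (Homo sapiens) for antiproliferative activity, read by sulforhodamine B assay, with a stated time of 3 days (a lower number here means that less compound is needed, a higher number that more compound is needed for the effect), compound 1 (`CCC1=C(O)c2c(oc(-c3ccc(C)cc3)cc2=O)C(CC)(CC)C1=O`) gives 39.2 uM. Compound 2 (`CCOc1ccc(-c2cc(=O)c3c(o2)C(CC)(CC)C(=O)C(CC)=C3O)cc1`) gives > 52.4 uM, which is a limit of the assay and not a number. Compound 3 (`CCC1=C(O)c2c(oc(-c3ccc(OC(F)(F)F)cc3)cc2=O)C(CC)(CC)C1=O`) differs from it by trifluoromethyl in place of ethyl on an oxygen on an aromatic ring, the change from ethoxy to trifluoromethoxy. Among the measured compounds shown here, only one measured step bears on this, the swap of ethoxy for methyl on an aromatic carbon, an at least 1.3-fold higher number from compound 1 to compound 2 (0.12 log units; that floor lies within the scatter). That small step gives no ground for a large move in this assay, so nothing beyond the scatter is expected, and the estimated step is an at least 1.0-fold lower number from compound 2 to compound 3 (0.02 log units; that floor lies within the scatter). Compound 3 is expected at 50 uM, with an estimated range of 25 uM to 100 uM.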

Compound 3, concentration for half-maximal effect: 36.5 uM
Compound 3: the middle estimate sits 1.4-fold (0.14 log units) above what was measured, and the stated range covers the measured number.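

Trifluoromethoxy at this place on the aromatic ring gives a number that can be read in this assay, whereas compound 2, with ethoxy, stays at a limit of the assay: the limit of > 52.4 uM in this assay, at which 1 of the 3 values shown sits. Trifluoromethyl in place of ethyl on the oxygen gives an at least 1.4-fold lower number from compound 2 to compound 3 (0.15 log units; that floor lies within the scatter) and, with only a floor to go on, the full size of this step remains unknown. Trifluoromethoxy in place of methyl gives a 1.1-fold lower number from compound 1 to compound 3 (0.03 log units; within the scatter) and thus does not separate these two compounds.

On these data alone, what an amine or a carboxylic acid at this place would do remains open. So does whether any group here can move the number beyond the scatter.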